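The compounds below may be only part of what the source reports. "The series", "measured", "known", "first", "only" and "open" are said of these compounds alone.

Measured so far:
compound 1 `Clc1ccc(Oc2ccc3nc(-c4ccc(OC5CCNCC5)cc4)oc3c2)cc1` — 20.6%
compound 2 `Clc1ccc(Oc2ccc3nc(-c4ccc(OCC5CCNCC5)cc4)oc3c2)cc1` — "not active" (no number reported)
compound 3 `CCN1CCC(Oc2ccc(-c3nc4ccc(Oc5ccc(Cl)cc5)cc4o3)cc2)CC1` — 15.3%

In an assay on isolated protein for inhibition of advanced glycosylation end product-specific receptor (Homo sapiens), read by FRET, with stated times of 30 min and 1 h, tested at 4 uM (a lower number here means less inhibition, a higher number more inhibition at the concentration tested (going by the name of the read-out)), compound 3 gives 15.3%, and compound 1 gives 20.6%. The step of a number 5.3 percentage points lower from compound 1 to compound 3 (within the scatter) lies within the scatter, so the two stand level. Compound 4 `CC(C)N1CCC(COc2ccc(-c3nc4ccc(Oc5ccc(Cl)cc5)cc4o3)cc2)CC1` differs from compound 3 by (1-isopropylpiperidin-4-yl)methyl in place of 1-ethylpiperidin-4-yl on an oxygen on an aromatic ring. Among the compounds with values here, no measured step covers this change. Within the data shown here, the only measured step, a number 5.3 percentage points lower from compound 1 to compound 3 (within the scatter), altered the group on the amine nitrogen and stayed within the scatter, so the isopropyl part is expected to matter little. Compound 2 has its piperidine joined to the oxygen through a methyl as in compound 4. In this assay compound 2 was reported as "not active" (no number reported), while compound 1 gives 20.6%. Inhibition for compound 4 is therefore expected to fall, possibly to no reported number. Compound 4 is estimated at 7% (range 0% to 20%), a step of a number 8.3 percentage points lower from compound 3 to compound 4 (within the scatter).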

Compound 4, a percentage reported as inhibition, at one concentration (the size of the read-out at that concentration, not a potency): 26.2%
Compound 4: middle estimate off by 19.2 percentage points, on the low side; measured number above the stated range.
By their numbers in this assay, from the lowest: compounds 3, 1 and 4 (each within the scatter of the next, the first and the last beyond it).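

In this assay the change on the oxygen to (1-isopropylpiperidin-4-yl)methyl gives a number 10.9 percentage points higher from compound 3 to compound 4 (beyond the scatter) and shows that this position accepts the larger group. Set against the plain piperidin-4-yl, the same group gives a number 5.6 percentage points higher from compound 1 to compound 4 (within the scatter) and the two stand level. Compound 2 has the same methyl link without the isopropyl and is reported as "not active" (no number reported) while compound 4 has a number, so the link alone does not decide the outcome.

Still open, as far as these compounds go, is how a longer chain to the piperidine, or an open-chain amine such as dimethylamino in place of the ring, would read. Nothing measured here explains the rise.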